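The source may report more compounds than this note shows. Statements on the series, on what has been measured and on what is new or still open speak of the compounds shown alone.

Measured so far in a functional assay on MDA-MB-231 cells (Homo sapiens) for antiproliferative activity, read by MTT assay, with a stated time of 72 h; a lower number here means a stronger inhibitor, a higher number a weaker inhibitor:
- compound 1 `CC1=CC[C@H]2[C@H](CC[C@]2(C)O)C(C)(C)[C@@H]1CC[C@H]1[C@]2(C)CC[C@H](OC(=O)c3ccc(C)cc3)C(C)(C)O[C@H]2CC[C@@]1(C)O`: 33400 nM
- compound 2 `CC1=CC[C@H]2[C@H](CC[C@]2(C)O)C(C)(C)[C@@H]1CC[C@H]1[C@]2(C)CC[C@H](OC(=O)NCc3ccccc3)C(C)(C)O[C@H]2CC[C@@]1(C)O`: 40300 nM
- compound 3 `CC1=CC[C@H]2[C@H](CC[C@]2(C)O)C(C)(C)[C@@H]1CC[C@H]1[C@]2(C)CC[C@H](OC(=O)NS(=O)(=O)c3ccc(C)cc3)C(C)(C)O[C@H]2CC[C@@]1(C)O`: 47100 nM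

These three compounds share one core and differ only in the group on a carbonyl carbon. Compound 3, at 47100 nM, cannot be told apart from the other two. The measured steps that reach it are a 1.4-fold higher number from compound 1 to compound 3 (0.15 log units; within the scatter) and a 1.2-fold higher number from compound 2 to compound 3 (0.07 log units; within the scatter).

The next compound, not yet measured, is compound 4 `CC1=CC[C@H]2[C@H](CC[C@]2(C)O)C(C)(C)[C@@H]1CC[C@H]1[C@]2(C)CC[C@H](OC(=O)c3ccc(F)cc3)C(C)(C)O[C@H]2CC[C@@]1(C)O`. The change is 4-fluorophenyl in place of ((4-methylphenyl)sulfonyl)amino on a carbonyl carbon. In words, it has 4-fluorophenyl in place of ((4-methylphenyl)sulfonyl)amino on a carbonyl carbon.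

The most useful guide is a 1.4-fold higher number from compound 1 to compound 3 (0.15 log units; within the scatter), since compound 1 also has a substituted phenyl group on that carbonyl carbon, and this step run backwards resembles the new change. The remaining step, a 1.2-fold higher number from compound 1 to compound 2 (0.08 log units; within the scatter), shows that a third group on that carbon also left the number within the scatter. Within the data shown here, no measured pair shows what fluorine does in place of methyl, so this part of the change remains untested. A step beyond the scatter is therefore not expected.

The estimated step is a 1.3-fold lower number from compound 3 to compound 4 (0.13 log units; within the scatter).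

For compound 4, the expected value is about 35000 nM, with an estimated range from 19000 nM to 65000 nM.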

Compound 4, half-maximal inhibitory concentration: 11300 nM
The estimate for compound 4 lay 3.1-fold (0.49 log units) above the measured number; measured number below the stated range.
By their numbers in this assay, from the lowest: compound 4; then compounds 1, 2 and 3 (each within the scatter of the next).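

In this assay, among these compounds, the group on this carbonyl carbon now shows an effect that the earlier compounds did not: fluoro in place of methyl on an aromatic carbon, a very small change, gives a 3.0-fold lower number from compound 1 to compound 4 (0.47 log units; beyond the scatter), the first step at this position beyond the scatter. Compound 4 also separates from the two compounds that carry a nitrogen on that carbonyl carbon, with a 3.6-fold lower number from compound 2 to compound 4 (0.55 log units; beyond the scatter) and a 4.2-fold lower number from compound 3 to compound 4 (0.62 log units; beyond the scatter), which makes compound 4 the strongest of the four in this assay, whereas the first three cannot be told apart. No measurement shown here accounts for this difference.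

On these data alone, the gain rests on a single swap, so it remains open whether fluoro itself matters or whether other groups on that aromatic carbon, such as chloro, methoxy or plain hydrogen, would give a similar number. As far as these compounds go, it also remains open how a fluoro group would behave on the benzylamino group of compound 2 or in the (4-methylphenyl)sulfonyl part of compound 3.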